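A few compounds are considered here, and "the series" means these few. Any claim that something is new, unique, unknown or untested is made for them only; others in the source may bear on it.

Compound 1 `COc1cc(C[C@H]2C(=O)OC[C@@H]2Cc2ccc(OC)c(OC)c2)ccc1N`: 2850 nM
Compound 2 `COc1cc(C[C@H]2C(=O)OC[C@@H]2Cc2ccc(OC)c(OC)c2)ccc1Nc1ccc(F)cc1`: > 50000 nM

Both compounds were tested in a functional assay on A549 cells (Homo sapiens) for cytotoxicity, read by MTT assay, with a stated time of 4 days; a lower number here means a stronger inhibitor, a higher number a weaker inhibitor. Compound 2 gives > 50000 nM, which is a limit of the assay and not a number. It is the weaker of the two, and it sits at the limit of > 50000 nM in this assay, at which 1 of the 2 values shown sits.

Compound 3 `COc1cc(C[C@H]2C(=O)OC[C@@H]2Cc2ccc(OC)c(OC)c2)ccc1NCc1ccccc1` keeps the shared core and alters only the group on the nitrogen: benzyl in place of 4-fluorophenyl on a nitrogen on an aromatic ring. This places benzyl where 4-fluorophenyl stood on a nitrogen on an aromatic ring.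

Among the compounds with values here, one measured step bears on this change: an at least 17-fold higher number from compound 1 to compound 2 (1.24 log units; beyond the scatter). That large step, beyond the scatter, came from replacing hydrogen on the same nitrogen with 4-fluorophenyl. Within the data shown here, no measured step tests benzyl, so a moderate move toward lower numbers is expected, while staying on the weak side.

The estimate for compound 3 is 15000 nM, with an expected range of 4000 nM to 50000 nM. This expectation amounts to an at least 3.3-fold lower number from compound 2 to compound 3 (0.52 log units; beyond the scatter).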

Compound 3, half-maximal inhibitory concentration: > 50000 nM
Compound 3 was reported as a limit; the forecaster's own chance of this, stated with the estimate: 30%; at least 3.3-fold (0.52 log units) between middle value and limit.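

Putting benzyl on this nitrogen in place of hydrogen gives an at least 17-fold higher number from compound 1 to compound 3 (1.24 log units; beyond the scatter) in this assay, so the loss seen with 4-fluorophenyl is not unique to that group: of the three compounds shown, only the one with the free amine gives a measurable value. Compound 3 gives > 50000 nM, which is a limit of the assay and not a number. The step between the two substituted compounds cannot be read, so they cannot be ranked against each other, and both stand at the same limit: the limit of > 50000 nM in this assay, at which 2 of the 3 values shown sit.

As far as these compounds go, it remains open whether a much smaller group on this nitrogen, such as methyl, would stay close to compound 1 or also reach the limit. The same question applies to a short chain ending in an amine or a carboxylic acid.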